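Carbonyl substituent step from compound 3 to compound 4

A few compounds are considered here, and "the series" means these few. Any claim that something is new, unique, unknown or untested is made for them only; others in the source may bear on it.

compound 1 `COc1ccc(CN(C(=O)C=C(C)C)c2cc(OC)c(OC)c(OC)c2)cc1O`: 280 nM
compound 2 `C#CC(=O)N(Cc1ccc(OC)c(O)c1)c1cc(OC)c(OC)c(OC)c1`: 570 nM
compound 3 `COc1ccc(CN(C(=O)CCl)c2cc(OC)c(OC)c(OC)c2)cc1O`: 210 nM

In a functional assay on KYSE-450 cells (Homo sapiens) for inhibition, read by MTT assay, with a stated time of 48 h (a higher number here means a weaker inhibitor, a lower number a stronger inhibitor), compound 3 gives 210 nM. It is not separated from compound 1, as a 1.3-fold lower number from compound 1 to compound 3 (0.12 log units; within the scatter) stays within the scatter, whereas a 2.7-fold lower number from compound 2 to compound 3 (0.43 log units; beyond the scatter) goes beyond it. Compound 4 `COc1ccc(CN(C(=O)C2CC2)c2cc(OC)c(OC)c(OC)c2)cc1O` carries cyclopropyl in place of chloromethyl on a carbonyl carbon. Among the compounds with values here, no measured compound has cyclopropyl there, so the guide is the size of the other changes at this carbonyl carbon, the largest being a 2.7-fold lower number from compound 2 to compound 3 (0.43 log units; beyond the scatter), with a 2.0-fold higher number from compound 1 to compound 2 (0.31 log units; beyond the scatter) also modest. The expected step is a 1.4-fold higher number from compound 3 to compound 4 (0.15 log units; within the scatter), none beyond the scatter. For compound 4 the estimated value is 300 nM, with an expected range of 120 nM to 750 nM.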

Compound 4, half-maximal inhibitory concentration: 80 nM
Estimate against measurement, compound 4: 3.8-fold (0.57 log units) above; measured number below the stated range.
By their numbers in this assay, from the lowest: compound 4; then compounds 3 and 1 (each within the scatter of the next); then compound 2.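

In this assay, a small saturated ring on the carbonyl carbon gives compound 4 the lowest number of the series, clear of all three open-chain groups (cyclopropyl in place of chloromethyl: a 2.6-fold lower number from compound 3 to compound 4 (0.42 log units; beyond the scatter); in place of 2-methylprop-1-en-1-yl: a 3.5-fold lower number from compound 1 to compound 4 (0.54 log units; beyond the scatter); in place of ethynyl: a 7.1-fold lower number from compound 2 to compound 4 (0.85 log units; beyond the scatter)). The last of these is the widest step yet seen at this position. No evidence on why cyclopropyl does better accompanies these results. Still open, as far as these compounds go, is whether the ring itself matters, which isopropyl or cyclobutyl on this carbonyl carbon would test.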